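A few compounds are considered here, and "the series" means these few. Any claim that something is new, unique, unknown or untested is made for them only; others in the source may bear on it.

Compound 1 `CCN1CCN(CCCn2cnc3c(N4CCN(CC)CC4)nc(N)nc32)CC1` sits second highest of the three numbers in hand in an assay on HEK293 cells for antagonist activity at Toll-like receptor 9 (Homo sapiens), read by spectrophotometry (on this read-out higher numbers stand for weaker inhibition and lower numbers for stronger inhibition), where compound 1 gives 260 nM. Its nearest neighbour is compound 3 `CCN1CCN(CCCn2cnc3c(N4CCN(C5CCCC5)CC4)nc(N)nc32)CC1`, which gives 280 nM; the step of a 1.1-fold higher number from compound 1 to compound 3 (0.03 log units; within the scatter) is within the scatter. Furthest away is compound 2 `CN(C)Cc1ccc(CNc2nc(N3CCN(C4CCCC4)CC3)c3ncn(CCCN4CCCC4)c3n2)cc1`, which gives 7 nM; compound 2 differs from compound 1 in several places at once, so no single step is defined, and its two values alone show that a much lower number is reachable within this series.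

Compound 4 `CCN1CCN(CCCn2cnc3c(N4CCN(CC)CC4)nc(NCc4ccc(F)cc4)nc32)CC1` differs from compound 1 by 4-fluorobenzyl in place of hydrogen on a nitrogen on an aromatic ring. Among the measured compounds shown here, no measured step isolates this change. For the measured compounds named here, the only bearing evidence is compound 2, whose benzyl-bearing amine accompanies 7 nM against 260 nM for compound 1, but those two compounds also differ elsewhere. A lower number for compound 4 is therefore expected, with considerable uncertainty, the estimated step being a 5.8-fold lower number from compound 1 to compound 4 (0.76 log units; beyond the scatter). For compound 4 the estimate in this assay is 45 nM, with a range from 10 nM to 200 nM.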

Compound 4, half-maximal inhibitory concentration: 470 nM
The estimate for compound 4 lay 10-fold (1.02 log units) below the measured number, and the stated range ends below it.
By their numbers in this assay, from the lowest: compound 2; then compounds 1, 3 and 4 (each within the scatter of the next).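

On a nitrogen on an aromatic ring, 4-fluorobenzyl in place of hydrogen gives a 1.8-fold higher number from compound 1 to compound 4 (0.26 log units; within the scatter) in this assay, the first single-place step shown at this position. Adding this group of 8 heavy atoms to the amino group of compound 1 therefore yields no step beyond the scatter, so the substitution alone does not separate the two compounds on this read-out. Nothing among the data shown offers an explanation for this result.

On these data alone, whether a plain benzyl or a phenethyl group on that nitrogen would also stay within the scatter remains open, as does whether 4-fluorobenzyl would give a similar step with cyclopentyl in place of ethyl on the ring amine nitrogen. Also unresolved is which of the several places in which compound 2 differs accounts for its 7 nM.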